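Methyl for nitro on a fused flavone-linked ring

This account rests on a few compounds, and the source may have more. Where it says the series, first, only, none or still open, it means among the compounds named here.

Compound 1 `Cc1cc(C)c2c(c1)CN(c1ccc3c(=O)cc(-c4ccccc4)oc3c1)CO2`: "not active" (no number reported)
Compound 2 `O=c1cc(-c2ccccc2)oc2cc(N3COc4c(cccc4[N+](=O)[O-])C3)ccc12`: 1.96%
Compound 3 `Cc1cccc2c1OCN(c1ccc3oc(-c4ccccc4)cc(=O)c3c1)C2`: 60.9%

In a functional assay on MCF7 cells (Homo sapiens) for inhibition, read by MTT assay, with a stated time of 48 h, tested at 15 ug/mL (on this read-out higher numbers stand for more inhibition of growth at the one concentration tested and lower numbers for less inhibition of growth), compound 2 gives 1.96%, the lowest of the two numbers reported; compound 3 sits well above it, and compound 1 is reported without a number. Compound 4 `Cc1cccc2c1OCN(c1ccc3c(=O)cc(-c4ccccc4)oc3c1)C2` differs from compound 2 by methyl in place of nitro on an aromatic carbon. Compound 1, which also carries methyl groups on the same core, returned no number, so the weight of the known values keeps expectations low. The step of a number 13 percentage points higher from compound 2 to compound 4 (beyond the scatter) is expected to be a small upward one, likely within the scatter or just beyond it. Compound 4 is therefore expected to give 15%, with a range from 0% to 45%.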

Compound 4, percent growth inhibition at one concentration: 54.9%
Estimate against measurement, compound 4: 39.9 percentage points below; the measured number lies above the stated range.
By their numbers in this assay, from the lowest: compound 2; then compounds 4 and 3 (each within the scatter of the next).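

In this assay methyl in place of nitro on this aromatic carbon gives a number 52.9 percentage points higher from compound 2 to compound 4 (beyond the scatter) on an otherwise unchanged core. Within the data shown here, this is the first pair differing in one place, and it shows that the group on this carbon alone can separate almost no growth inhibition from substantial inhibition. Nothing measured here explains the size of this step. Whether the gain comes from having methyl or from losing nitro stays open: the compounds shown leave unknown how an amine, a methoxy group or a longer chain would fare on this carbon.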